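Chloro for fluoro on the phenoxy ring: acid dissociation

The source may hold more compounds than are shown below. What is called first, only, known or untested is meant among the compounds shown, and "the series" means these compounds.

In a physicochemical assay for acid dissociation, compound 2 `COc1ccc(F)cc1CNCCCNc1ccnc2cc(Oc3ccc(F)cc3)ccc12` stands at 9.28, and compound 1 `COc1ccc(F)cc1CNCCCNc1ccnc2cc(Cc3cc(C)cc(C)c3)ccc12` at 9.47; the two numbers sit within the scatter of each other, as the step of a number 0.19 log units lower from compound 1 to compound 2 (within the scatter) shows. Compound 3 `COc1ccc(F)cc1CNCCCNc1ccnc2cc(Oc3ccc(Cl)cc3)ccc12` differs from compound 2 by chloro in place of fluoro on an aromatic carbon. Within the data shown here, the one measured step concerned the same aromatic carbon and a far larger exchange of groups, yet stayed within the scatter, so no step beyond the scatter is expected here, a number 0.02 log units higher from compound 2 to compound 3 (within the scatter). Compound 3 is therefore estimated at 9.3, within 9 to 9.6.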

Compound 3, acid dissociation constant: 9.28
For compound 3 the middle estimate is 0.02 log units above the measured one; measured number inside the range.
By their numbers in this assay, from the lowest: compounds 2, 3 and 1 (each within the scatter of the next).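

Chloro in place of fluoro on the aromatic carbon of the phenoxy ring gives, in this assay, no change at the digits printed from compound 2 to compound 3 (within the scatter) and so the first exchange of one halogen for another at this position leaves the read-out unmoved. The larger exchange, 4-chlorophenoxy in place of 3,5-dimethylbenzyl, gives a number 0.19 log units lower from compound 1 to compound 3 (within the scatter) and thus also stays within the scatter. No measurement here bears on why these numbers stay so close.

Going by these compounds, whether an amine or a carboxylic acid in place of chloro on that aromatic carbon would also stay within the scatter remains open.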